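Nitro in place of methoxy on an aromatic carbon

The compounds below may be only part of what the source reports. "The series", "measured", "known", "first", "only" and "open" are said of these compounds alone.

In a functional assay on MCF7 cells (Homo sapiens) for antiproliferative activity, read by MTT assay, with a stated time of 24 h (a lower number here means a stronger inhibitor, a higher number a weaker inhibitor), compound 1 (`FC(F)(F)c1ccc(-c2nn(-c3ccccc3)cc2-c2nc3ccccc3[nH]2)cc1`) gives 6330 nM and compound 2 (`Cc1ccc(-c2nn(-c3ccccc3)cc2-c2nc3ccccc3n2S(=O)(=O)c2ccc(Cl)cc2)cc1`) gives 5930 nM as its reading, two values that lie within the usual scatter of each other. Compound 3 (`COc1ccc(S(=O)(=O)n2c(-c3cn(-c4ccccc4)nc3-c3ccc(F)cc3)nc3ccccc32)cc1`) gives 530 nM as the lowest of the three numbers, and both of the others stand beyond the scatter from it. That makes compound 3 the strongest inhibitor measured so far.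

Compound 4 (`O=[N+]([O-])c1ccc(S(=O)(=O)n2c(-c3cn(-c4ccccc4)nc3-c3ccc(F)cc3)nc3ccccc32)cc1`) departs from compound 3 at one place: nitro in place of methoxy on an aromatic carbon (nitro in place of methoxy on an aromatic carbon, para to a large group). Put another way, 4-methoxyphenyl becomes 4-nitrophenyl. For the measured compounds named here, no measured pair isolates this change, since compound 2 and compound 3 differ in more than one place. The estimate therefore starts from compound 3 at 530 nM and stays cautious, with a wide range on either side. In this assay a modest shift toward a higher number is expected, only slightly beyond the scatter. The expected step of a 2.3-fold higher number from compound 3 to compound 4 (0.35 log units; beyond the scatter) is accordingly small, although a move in the opposite direction cannot be excluded. The estimated value for compound 4 is 1200 nM within an expected range of 300 nM to 4500 nM for this reading.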

Compound 4, half-maximal inhibitory concentration: 1370 nM
Beside the measured number, compound 4's estimate is 1.1-fold (0.06 log units) below it; low and high end bracket the measured number.
By their numbers in this assay, from the lowest: compound 3; then compound 4; then compounds 2 and 1 (each within the scatter of the next).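

For the compounds shown here, compound 3 and compound 4 form the first measured pair that differs in one place, so this change can now be read directly. In this assay, nitro in place of methoxy on the aromatic carbon gives a 2.6-fold higher number from compound 3 to compound 4 (0.41 log units; beyond the scatter), which shows that this place is not indifferent to the group it carries, although the step is modest and compound 4 does not lose activity altogether. No measurement of any property of either group is at hand to account for this step.

From the compounds shown here alone, with only methoxy and nitro read against each other at this place, the pair gives two points and no trend, so it remains open how an amine, a carboxylic acid or a nitrile on the same aromatic carbon would read. Going by these compounds, it is also open whether the same exchange would give a step of similar size with a different group elsewhere on the shared core.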